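Indazole for Indole: What to Expect from Compound 4

The compounds below may be only part of what the source reports. "The series", "measured", "known", "first", "only" and "open" are said of these compounds alone.

Of the compounds shown here, three built on one shared core have been tested in a functional assay on MV4-11 cells (Homo sapiens) for antiproliferative activity, read by resazurin assay, with a stated time of 72 h; on this read-out lower numbers stand for stronger inhibition of growth and higher numbers for weaker inhibition of growth. Compound 1 `CC(=O)N1CCN(c2ccc(Nc3ncc(C#N)c(-c4n[nH]c5ccccc45)n3)cc2)CC1` gives 17 nM. Compound 2 `CC(=O)N1CCN(c2ccc(Nc3ncc(C#N)c(-c4cn(C)c5ccccc45)n3)cc2)CC1` gives 30 nM. Compound 3 `CC(=O)N1CCN(c2ccc(Nc3nccc(-c4cn(C)c5ccccc45)n3)cc2)CC1` gives 252 nM, the highest number of the three, with both of the others clearly lower.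

Compound 2 and compound 1 differ in a single place: 1H-indazol-3-yl in place of 1-methyl-1H-indol-3-yl on an aromatic carbon. That change produced a 1.8-fold lower number from compound 2 to compound 1 (0.25 log units; within the scatter). Compound 2 and compound 3 differ in their cores: hydrogen in place of cyano on an aromatic carbon. That change produced an 8.4-fold higher number from compound 2 to compound 3 (0.92 log units; beyond the scatter), a markedly weaker inhibition of growth.

Compound 4 `CC(=O)N1CCN(c2ccc(Nc3nccc(-c4n[nH]c5ccccc45)n3)cc2)CC1` has not yet been measured. It stands to compound 3 as compound 1 stands to compound 2: 1H-indazol-3-yl in place of 1-methyl-1H-indol-3-yl on an aromatic carbon. The surroundings of the exchanged group are not identical, though. In the measured pair the place is "ortho to a cyano group", while in compound 3 and compound 4 there is no cyano group at that place, so this is the same kind of change rather than the very same change.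

For compound 4 a step of similar, small size is expected, a 1.7-fold lower number from compound 3 to compound 4 (0.23 log units; within the scatter). Among the compounds with values here, that expectation rests on the small step of a 1.8-fold lower number from compound 2 to compound 1 (0.25 log units; within the scatter), which was the only time this exchange was observed. Compound 4 is therefore estimated at 150 nM, most likely falling between 60 nM and 400 nM.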

Compound 4, concentration for 50% growth inhibition: 346 nM
Estimate against measurement, compound 4: 2.3-fold (0.36 log units) below; the measured number falls inside the stated range.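

In this assay, putting 1H-indazol-3-yl in place of 1-methyl-1H-indol-3-yl on the core without the cyano group gave a 1.4-fold higher number from compound 3 to compound 4 (0.14 log units; within the scatter), so on neither core did this exchange move the number beyond the scatter, and the two steps agree: the same change on two cores in this assay, a 1.8-fold lower number (0.25 log units; within the scatter) from compound 2 to compound 1 and a 1.4-fold higher number (0.14 log units; within the scatter) from compound 3 to compound 4, 2.4-fold (0.38 log units) apart, within the scatter of two such steps. Taking away the cyano group carried over as well, giving a 20-fold higher number from compound 1 to compound 4 (1.31 log units; beyond the scatter), a large loss of growth inhibition in the same direction as the one seen with the 1-methyl-1H-indol-3-yl group, and again the two steps agree: the same change on two cores in this assay, an 8.4-fold higher number (0.92 log units; beyond the scatter) from compound 2 to compound 3 and a 20-fold higher number (1.31 log units; beyond the scatter) from compound 1 to compound 4, 2.4-fold (0.38 log units) apart, within the scatter of two such steps. Within these four compounds, then, each change behaves much the same whichever form the other part takes, but this rests on a single pair of steps per change in one cell assay, so it shows neither why the numbers move nor that the same would hold on any other core.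

The compounds shown leave open what other groups would do in place of the cyano group, such as a fluorine atom, a chlorine atom or a carboxamide. They also leave open how a plain 1H-indol-3-yl group, without the methyl, would compare with the two groups exchanged here.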